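Benzylsulfanyl variation on the shared core: half-life notes

This account rests on a few compounds, and the source may have more. Where it says the series, first, only, none or still open, it means among the compounds named here.

Working notes on the series. In an ADME assay on microsomes from liver (Homo sapiens) for metabolic stability, read by LC-MS, using NADPH, tested at 5 uM (on this read-out lower numbers stand for a shorter-lived compound and higher numbers for a longer-lived compound), compound 1 `Cc1cccc(CSc2cc(Cl)c(C)cc2S(=O)(=O)/N=C(\N)n2nccc2-c2ccccc2)c1` gives 0.232 h. Compound 3 `Cc1cccc(CSc2cc(Cl)c(C)cc2S(=O)(=O)/N=C(\N)n2nc(C)cc2-c2ccccc2)c1` gives 0.214 h and compound 2 `Cc1ccc(CSc2cc(Cl)c(C)cc2S(=O)(=O)/N=C(\N)n2nc(C)cc2-c2ccccc2)cc1` gives 0.176 h. Of the three numbers that of compound 1 sits highest, but the spread is narrow: a 1.1-fold lower number from compound 1 to compound 3 (0.04 log units; within the scatter), and the two values of compound 1 and compound 2 also lie within the scatter of each other. Compound 4 `Cc1cc(S(=O)(=O)/N=C(\N)n2nccc2-c2ccccc2)c(SCc2ccc(Cl)cc2)cc1Cl` is not yet measured; it differs from compound 1 as follows: 4-chlorophenyl in place of 3-methylphenyl on a saturated chain carbon bound to a sulfur. Going by the values given here, the one measured step at the same place is a 1.2-fold higher number from compound 2 to compound 3 (0.08 log units; within the scatter), within the scatter, and the only other measured step, methyl in place of hydrogen on an aromatic carbon, was likewise within the scatter. Among the compounds with values here, no measured step covers a chlorine entering this ring, so the expectation rests on the small size of the steps seen so far. For compound 4 the expected step is a 1.1-fold lower number from compound 1 to compound 4 (0.04 log units; within the scatter), nothing beyond the scatter. Compound 4 is estimated in this assay at 0.21 h, with a range from 0.11 h to 0.42 h.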

Compound 4, half-life: 0.34 h
Estimate against measurement, compound 4: 1.6-fold (0.21 log units) below; low and high end bracket the measured number.
By their numbers in this assay, from the lowest: compounds 2, 3, 1 and 4 (each within the scatter of the next).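

In this assay, the exchange of 3-methylphenyl for 4-chlorophenyl on a saturated chain carbon bound to a sulfur gives a 1.5-fold higher number from compound 1 to compound 4 (0.17 log units; within the scatter) on the shared core. Going by these compounds alone, this is the first step at this position in which a chlorine enters the ring and the methyl leaves it, and it stays within the scatter, as does the move of the methyl in a 1.2-fold higher number from compound 2 to compound 3 (0.08 log units; within the scatter) at the same place. Nothing available accounts for the size of this step or ties it to any property of the chlorine.

As far as these compounds go, whether the same exchange reads alike on the core of compound 3 stays open. Also open, from the compounds shown here alone, is whether an amine or a carboxylic acid on this ring, or a longer chain in place of the benzyl group, would move the half-life beyond the scatter.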